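The source may hold more compounds than are shown below. What is called first, only, known or untested is meant among the compounds shown, and "the series" means these compounds.

Compound 1, `Cc1cc(-n2cc(C(=O)Nc3cc(F)cc(F)c3)c(=O)c3ccc(N(C)C)nc32)ccc1OCCCCCCC[N+]1(C)CCCC1`, and compound 2, `Cc1cc(-n2cc(C(=O)Nc3cc(F)cc(F)c3)c(=O)c3ccc(N(C)C)nc32)ccc1OCCCCCCC[n+]1ccccc1`, share one core and differ only in the charged ring at the end of the chain. In an assay on LX2 cells for inhibition of COL1A1 promoter (Homo sapiens), read by a luciferase reporter, with a stated time of 24 h, tested at 20 uM (on this read-out lower numbers stand for a weaker effect and higher numbers for a stronger effect at the one concentration tested), compound 1 gives 26.1%. Compound 2 is reported in this assay only as "not active" (no number reported), so no single number marks where it stands. Compound 3, `Cc1cc(-n2cc(C(=O)Nc3cc(F)cc(F)c3)c(=O)c3ccc(N(C)C)nc32)ccc1OCCCCCCC[N+]1(C)CCN(C)CC1`, carries the change (a group of 8 heavy atoms (6 carbon, 2 nitrogen; one six-membered non-aromatic ring with 2 hetero atoms) in place of a group of 6 heavy atoms (5 carbon, 1 nitrogen; one six-membered aromatic ring with 1 hetero atom), on a saturated chain carbon, seven bonds along the chain from an oxygen on an aromatic ring). Among the compounds with values here, no measured step fits this change, so the expectation rests on compound 1 alone, whose saturated charged ring gives 26.1%; a modest rise from compound 2 is expected. For compound 3 the estimated inhibition is 20%, with a range from 0% to 45%.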

Compound 3, a percentage reported as inhibition, at one concentration (the size of the read-out at that concentration, not a potency): 16.2%
For compound 3 the middle estimate is 3.8 percentage points above the measured one; low and high end bracket the measured number.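

In this assay the swap of saturated rings gives a number 9.9 percentage points lower from compound 1 to compound 3 (within the scatter), so at this position, on a saturated chain carbon, the six-membered non-aromatic ring with 2 hetero atoms and the five-membered non-aromatic ring with 1 hetero atom cannot be told apart. Compound 3 thus gives a number, as compound 1 does, while compound 2, with its six-membered aromatic ring, is reported only as not active. Nothing available explains this difference. From the compounds shown here alone, how a morpholine ring or a shorter chain would read here remains open.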